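Removing the ring nitrogen methyl from a dimethylpiperazine

The source may report more compounds than this note shows. Statements on the series, on what has been measured and on what is new or still open speak of the compounds shown alone.

Measured compounds:
- Compound 1 `COc1cc2c(cc1N1CCN(C)CC1)N(C(=O)c1ccc(-c3cccc(C)n3)c3ccccc13)CC2`: 25.1 nM
- Compound 2 `COc1cc2c(cc1N1C[C@@H](C)N(C)[C@@H](C)C1)N(C(=O)c1ccc(-c3cccc(C)n3)c3ccccc13)CC2`: 100 nM

In an assay on isolated protein for binding affinity to 5-hydroxytryptamine receptor 1D (Homo sapiens) (on this read-out higher numbers stand for weaker inhibition and lower numbers for stronger inhibition), compound 1 gives 25.1 nM, the lowest of the two numbers recorded; its nearest neighbour is compound 2, which in this assay gives 100 nM. Among the compounds with values here, the one measured step, a 4.0-fold higher number from compound 1 to compound 2 (0.60 log units; beyond the scatter), comes from adding two methyl groups to the piperazine ring while keeping the methyl on its nitrogen.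

Compound 3 `COc1cc2c(cc1N1C[C@@H](C)N[C@@H](C)C1)N(C(=O)c1ccc(-c3cccc(C)n3)c3ccccc13)CC2` has not yet been measured. It differs from compound 1 by 3,5-dimethylpiperazin-1-yl in place of 4-methylpiperazin-1-yl on an aromatic carbon. Within the data shown here, this change shares the two ring methyl groups with compound 2, but it also takes away the methyl on the piperazine nitrogen, and no measured pair shows what that removal alone does. Among the measured compounds shown here, the step of a 4.0-fold higher number from compound 1 to compound 2 (0.60 log units; beyond the scatter) is therefore the only guide, and it points towards a weaker binding number.

Compound 3 is therefore expected to give about 80 nM in this assay, with a range of 25 nM to 250 nM; the estimated step is a 3.2-fold higher number from compound 1 to compound 3 (0.50 log units; beyond the scatter), a modest loss resembling that from compound 1 to compound 2.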

Compound 3, inhibition constant: 126 nM
The estimate for compound 3 lay 1.6-fold (0.20 log units) below the measured number; low and high end bracket the measured number.
By their numbers in this assay, from the lowest: compound 1; then compounds 2 and 3 (each within the scatter of the next).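

On the aromatic carbon ortho to a methoxy group, replacing 4-methylpiperazin-1-yl with 3,5-dimethylpiperazin-1-yl gives a weaker result in this assay (a 5.0-fold higher number from compound 1 to compound 3 (0.70 log units; beyond the scatter)). The new pair also isolates the methyl on the ring nitrogen: replacing it with hydrogen, with both ring methyl groups in place, gives a 1.3-fold higher number from compound 2 to compound 3 (0.10 log units; within the scatter), so compounds 2 and 3 cannot be told apart in this assay and, in this setting, the nitrogen methyl has no effect that can be resolved. Both compounds that carry the two ring methyl groups therefore give a higher number than compound 1, whichever group sits on the nitrogen, although no evidence is available to explain this link.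

From the compounds shown here alone, it remains open whether the nitrogen methyl matters when the ring methyl groups are absent, a question that the parent piperazin-1-yl group, with hydrogen on the nitrogen and no ring methyl groups, would address. It is also unknown whether a single ring methyl group, as in 3-methylpiperazin-1-yl, would be enough to give the higher number seen with two.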